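Hydroxy(phenyl)methyl replacing phenyl on a carbonyl carbon

The source may report more compounds than this note shows. Statements on the series, on what has been measured and on what is new or still open speak of the compounds shown alone.

The three measured compounds share a core and differ only in the group on the ester carbonyl carbon. Compound 1 `O=C(OC1(C(=O)Nc2ccc([N+](=O)[O-])cc2)CCCCC1)c1ccc(Cl)cc1` gives 355 nM in an ADME assay on WI-38 cells (Homo sapiens) for inhibition, read by MTT assay, with a stated time of 72 h; on this read-out lower numbers stand for stronger inhibition and higher numbers for weaker inhibition. Compound 2 `O=C(/C=C/c1ccccc1)OC1(C(=O)Nc2ccc([N+](=O)[O-])cc2)CCCCC1` gives 41 nM in this assay, and compound 3 `O=C(OC1(C(=O)Nc2ccc([N+](=O)[O-])cc2)CCCCC1)c1ccccc1` gives 246 nM. Compound 3 thus stands second highest of the three numbers: its nearest neighbour is compound 1, within the scatter, while its furthest is compound 2, a step described by a 6.0-fold higher number from compound 2 to compound 3 (0.78 log units; beyond the scatter).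

Compound 4 `O=C(OC1(C(=O)Nc2ccc([N+](=O)[O-])cc2)CCCCC1)C(O)c1ccccc1` differs from compound 3 by hydroxy(phenyl)methyl in place of phenyl on a carbonyl carbon. Among the measured compounds shown here, the steps that bear on this site are an 8.7-fold lower number from compound 1 to compound 2 (0.94 log units; beyond the scatter) and a 6.0-fold higher number from compound 2 to compound 3 (0.78 log units; beyond the scatter), both modest and both beyond the scatter, whereas a 1.4-fold lower number from compound 1 to compound 3 (0.16 log units; within the scatter) changed nothing outside the scatter. For the measured compounds named here, no measured pair shows a hydroxy(phenyl)methyl group, so the direction is uncertain; a step no larger than modest is expected in this assay. Compound 4 is therefore estimated at 250 nM, with a range from 80 nM to 800 nM, which is the expected step of a 1.0-fold higher number from compound 3 to compound 4 (0.01 log units; within the scatter).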

Compound 4, half-maximal inhibitory concentration: 84.4 nM
Beside the measured number, compound 4's estimate is 3.0-fold (0.47 log units) above it; low and high end bracket the measured number.
By their numbers in this assay, from the lowest: compound 2; then compound 4; then compounds 3 and 1 (each within the scatter of the next).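

In this assay, hydroxy(phenyl)methyl on the carbonyl carbon separates from both aromatic groups attached there directly, giving a 2.9-fold lower number from compound 3 to compound 4 (0.46 log units; beyond the scatter) and a 4.2-fold lower number from compound 1 to compound 4 (0.62 log units; beyond the scatter) on this read-out. Until now only 2-phenylethenyl had stood apart from phenyl and 4-chlorophenyl at this position, so a second, different group now does so, and this one carries a hydrogen-bond donor that the others lack. It does not match 2-phenylethenyl, however, as there is a 2.1-fold higher number from compound 2 to compound 4 (0.31 log units; beyond the scatter) in the same comparison.

As far as these compounds go, whether the hydroxy group or the added carbon carries the step stays open, and a benzyl or a methoxy(phenyl)methyl group at this carbon would be needed to separate the two. The compounds shown hold no measurement that explains any of these steps.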